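This account rests on a few compounds, and the source may have more. Where it says the series, first, only, none or still open, it means among the compounds named here.

Measured compounds in an ADME assay on microsomes from liver (Homo sapiens) for metabolic stability, with a stated time of 10 min; on this read-out lower numbers stand for a less stable compound and higher numbers for a more stable compound:
compound 1 `CC(C)C(=O)NCCS(=O)(=O)NC(=O)c1ccc(Nc2nc(NC3(c4ccc(Cl)cc4)CC3)nc(OCC(F)(F)F)n2)cc1` gives 86%
compound 2 `CNC(=O)NCCS(=O)(=O)NC(=O)c1ccc(Nc2nc(NC3(c4ccc(Cl)cc4)CC3)nc(OCC(F)(F)F)n2)cc1` gives 97%
compound 3 `CS(=O)(=O)NC(=O)c1ccc(Nc2nc(NC3(c4ccc(Cl)cc4)CC3)nc(OCC(F)(F)F)n2)cc1` gives 100%

Compound 3 holds the highest of the three numbers; against compound 2 the difference is a number 3 percentage points higher from compound 2 to compound 3 (within the scatter), and against compound 1 it is a number 14 percentage points higher from compound 1 to compound 3 (beyond the scatter). Between the two lower compounds the change is a number 11 percentage points higher from compound 1 to compound 2 (beyond the scatter). All three measured steps alter the group bound to the sulfonyl sulfur, and none of them lowers the number beyond the scatter.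

Compound 4 `O=C(NS(=O)(=O)C1CC1)c1ccc(Nc2nc(NC3(c4ccc(Cl)cc4)CC3)nc(OCC(F)(F)F)n2)cc1` differs from compound 3 in one place: cyclopropyl in place of methyl on a sulfonyl sulfur. Among the measured compounds shown here, no measured step replaces methyl by cyclopropyl on a sulfonyl sulfur, so the bearing steps are indirect: the nearest are the step from compound 2 to compound 3 and the step from compound 1 to compound 3, both of which prune the chain on the sulfonyl sulfur and either raise the number or leave it within the scatter. Compound 3 already stands at the top of the range, so in this assay the step for compound 4 is expected to be a number 4 percentage points lower from compound 3 to compound 4 (within the scatter), within the scatter. For compound 4 the estimate is 96%, with a range from 86% to 100%.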

Compound 4, percent of the compound remaining: 100%
For compound 4 the middle estimate is 4 percentage points below the measured one; measured number inside the range.
By their numbers in this assay, from the lowest: compound 1; then compounds 2, 3 and 4 (each within the scatter of the next).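

In this assay, cyclopropyl in place of methyl on a sulfonyl sulfur gives no change at the digits printed from compound 3 to compound 4 (within the scatter), so a three-membered non-aromatic ring of carbon only can stand at this position without a loss beyond the scatter. Among the compounds shown here, the ring also gives a number 3 percentage points higher from compound 2 to compound 4 (within the scatter) against the 2-((methylcarbamoyl)amino)ethyl chain and a number 14 percentage points higher from compound 1 to compound 4 (beyond the scatter) against the 2-((isopropylcarbonyl)amino)ethyl chain, which leaves compound 1 as the only compound here set apart from the others by more than the scatter. Nothing on hand accounts for these numbers.

Compound 4 gives 100%, the same printed number as compound 3 with 100%, so this read-out cannot separate the two groups. Going by these compounds, whether phenyl, a longer unbranched alkyl chain or a chain ending in a carboxylic acid or an amine would hold the number on the sulfonyl sulfur remains open.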